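Urea series on KM12 cells: trifluoromethyl removal

The compounds below may be only part of what the source reports. "The series", "measured", "known", "first", "only" and "open" are said of these compounds alone.

Measured so far:
compound 1, `O=C(Nc1cccc(-n2cc(-c3ccncc3)c(-c3cc(O)cc(Cl)c3)n2)c1)Nc1ccc(Cl)c(Cl)c1`, 2.26%
compound 2, `COc1cc(Cl)cc(-c2nn(-c3cccc(NC(=O)Nc4cc(C(F)(F)F)cc(C(F)(F)F)c4)c3)cc2-c2ccncc2)c1`, 12.2%

Both compounds were read in a functional assay on KM12 cells (Homo sapiens) for inhibition, read by sulforhodamine B assay, with a stated time of 48 h, tested at 10 uM; a higher number here means a weaker effect of the compound at the concentration tested, a lower number a stronger effect. Compound 1 gives 2.26% and compound 2 gives 12.2%. For the measured compounds named here, on the numbers so far, compound 2 holds the highest of the two values, with compound 1 the nearest, its value lower by an amount that lies within the scatter, so the two cannot be ranked against each other.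

Compound 3, `COc1cc(Cl)cc(-c2nn(-c3cccc(NC(=O)Nc4cccc(C(F)(F)F)c4)c3)cc2-c2ccncc2)c1`, has not yet been measured in this assay. It differs from compound 2 in one place: hydrogen in place of trifluoromethyl on an aromatic carbon. The hydrogen enters on an aromatic carbon of a six-membered aromatic ring of carbon only, meta to a large group and meta to a trifluoromethyl group. Going by the values given here, no pair of measured compounds yet shows what such a change does in this assay, and nothing in the two values above speaks for a large shift in either direction.

The step from compound 2 to compound 3 in this assay is expected to be small, a number 3.2 percentage points lower from compound 2 to compound 3 (within the scatter), and not beyond the scatter. Compound 3 is therefore estimated at 9%, within a range from 0% to 28%.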

Compound 3, a percentage reported as activity, at one concentration (the size of the read-out at that concentration, not a potency): 9.81%
Beside the measured number, compound 3's estimate is 0.8 percentage points below it, and the stated range covers the measured number.
By their numbers in this assay, from the lowest: compounds 1, 3 and 2 (each within the scatter of the next).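

In this assay, the series now has its first pair differing in one place, and hydrogen in place of trifluoromethyl on an aromatic carbon gives a number 2.4 percentage points lower from compound 2 to compound 3 (within the scatter). At this place, meta to a large group and meta to a trifluoromethyl group, one of the two trifluoromethyl groups can therefore be lost without a change that can be read at the single concentration tested, though this read-out is not a potency and a shift visible only at lower concentrations would not appear here. No measurement is at hand that bears on this result or accounts for it.

The pair leaves open whether a methoxy group, an amine or a carboxylic acid at this place would hold the read-out as hydrogen does, and whether the remaining trifluoromethyl group can also give way to hydrogen. On these data alone, compound 1 differs from compound 2 and compound 3 in more than one place, so its steps to them cannot be read, and the separate effects of the hydroxy group and the two chlorines of compound 1 remain open.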